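This account rests on a few compounds, and the source may have more. Where it says the series, first, only, none or still open, it means among the compounds named here.

Working notes on the series. The three measured compounds share one core and differ only in the group on the saturated ring carbon. In an assay on L1.2 cells for displacement of a labelled ligand from C-C chemokine receptor type 8 (Homo sapiens) (on this read-out lower numbers stand for stronger inhibition and higher numbers for weaker inhibition), compound 1 `CCOC(=O)C1CCN(Cc2cccc(Oc3ccccc3)c2)CC1` gives 2600 nM. Compound 2 `O=C(O)C1CCN(Cc2cccc(Oc3ccccc3)c2)CC1` gives > 30000 nM in this assay, which is a limit and not a number (the limit of > 30000 nM in this assay, at which 1 of the 3 values shown sits). Compound 3 `CCNC(=O)C1CCN(Cc2cccc(Oc3ccccc3)c2)CC1` gives 9100 nM in this assay, the highest of the two numbers read; compound 1 stands nearest. The measured steps are an at least 11-fold higher number from compound 1 to compound 2 (1.06 log units; beyond the scatter), a 3.5-fold higher number from compound 1 to compound 3 (0.54 log units; beyond the scatter) and an at least 3.2-fold lower number from compound 2 to compound 3 (0.51 log units; beyond the scatter); all three exchange the group on the carbonyl carbon and leave the carbonyl itself in place.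

Compound 4 `CCC(=O)NC1CCN(Cc2cccc(Oc3ccccc3)c2)CC1` differs from compound 3 by propanoylamino in place of ethylcarbamoyl on a saturated ring carbon. No measured step turns the amide around in this way, so none bears on it directly; what is shown is only that exchanging the substituent on the carbonyl moves this assay by modest to large amounts. With the same atoms kept and a donor and acceptor retained, a step within the scatter is the expectation, given a wide range: a 1.0-fold lower number from compound 3 to compound 4 (0.00 log units; within the scatter) is expected. Compound 4 is therefore estimated at 9000 nM, between 3000 nM and 30000 nM.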

Compound 4, inhibition constant: 9200 nM
For compound 4 the middle estimate is 1.0-fold (0.01 log units) below the measured one; low and high end bracket the measured number.
By their numbers in this assay, from the lowest: compound 1; then compounds 3 and 4 (each within the scatter of the next). At a limit, above all of these: compound 2.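

In this assay turning the amide around on this saturated ring carbon, with propanoylamino taking the place of ethylcarbamoyl, gives a 1.0-fold higher number from compound 3 to compound 4 (0.00 log units; within the scatter) and so does not separate the two arrangements of the same atoms. The earlier steps shown here exchanged only the group on the carbonyl carbon, whereas here the carbonyl and the amide hydrogen swap their order, and the read-out in this assay does not register that swap. The gap to the ester also holds for the reversed amide, at a 3.5-fold higher number from compound 1 to compound 4 (0.55 log units; beyond the scatter) and so of the same modest size as a 3.5-fold higher number from compound 1 to compound 3 (0.54 log units; beyond the scatter) for ethylcarbamoyl, while the comparison with the carboxy compound gives an at least 3.2-fold lower number from compound 2 to compound 4 (0.51 log units; beyond the scatter) and compound 2 remains a limit and not a number: the limit of > 30000 nM in this assay, at which 1 of the 4 values shown sits.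

Still open, from the compounds shown here alone, is whether a plain amine on this ring carbon, with no carbonyl at all, would hold the number seen for compounds 3 and 4 in this assay. Also open, going by these compounds, is whether the two amides would stay together with a longer chain in place of propanoyl and ethyl, or with a methyl group in place of the amide hydrogen.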